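The source may report more compounds than this note shows. Statements on the series, on what has been measured and on what is new or still open speak of the compounds shown alone.

Measured so far in a functional assay for inhibition, with Rattus norvegicus as the target (on this read-out higher numbers stand for weaker inhibition and lower numbers for stronger inhibition), with the two compounds below:
Compound 1 `CC(C)(C)/N=c1\c(O)c(O)\c1=N/Cc1ccc(C#N)c(Cl)c1` gives 1100 nM
Compound 2 `CC[C@@H](C)/N=c1\c(O)c(O)\c1=N/Cc1ccc(C#N)cc1` gives 4000 nM

Of these two, compound 2 at 4000 nM carries the higher number and so the weaker inhibition, and the gap to compound 1 lies beyond the scatter. The next compound to read is compound 3 `CC(C)(C)/N=c1\c(O)c(O)\c1=N/Cc1ccc(C#N)cc1` and the change leading to it is tert-butyl in place of sec-butyl on a double-bonded nitrogen with tert-butyl in place of sec-butyl on a double-bonded nitrogen.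

Going by the values given here, no measured pair differs in one place only, so no direct step sets the size of this change. Among the compounds with values here, the only guide is that compound 1, which also bears tert-butyl, gives 1100 nM in this assay but that value cannot be read as the effect of this change alone. A small move toward a lower number is therefore expected, probably not clearly beyond the scatter. The expected step is a 1.8-fold lower number from compound 2 to compound 3 (0.26 log units; within the scatter) on this thin evidence. Compound 3 is estimated at 2200 nM with 700 nM to 6000 nM as the expected range.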

Compound 3, half-maximal inhibitory concentration: 270 nM
The estimate for compound 3 lay 8.1-fold (0.91 log units) above the measured number; measured number outside the range, below it.
By their numbers in this assay, from the lowest: compound 3; then compound 1; then compound 2.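

In this assay, the group on the double-bonded nitrogen proves to be a highly sensitive place in the series: tert-butyl in place of sec-butyl gives a 15-fold lower number from compound 2 to compound 3 (1.17 log units; beyond the scatter), although the two groups have the same atoms joined differently and the change removes the one defined stereocentre. On the aromatic carbon, with tert-butyl held constant, hydrogen in place of chloro gives a 4.1-fold lower number from compound 1 to compound 3 (0.61 log units; beyond the scatter), a modest step that is still beyond the scatter and leaves compound 3 as the strongest inhibitor of the three. No supporting data explain either step.

As far as these compounds go, it remains open whether the sec-butyl result reflects this one stereoisomer, since the mirror-image sec-butyl group, isopropyl, cyclobutyl and a longer chain such as n-butyl would be needed to define what the nitrogen tolerates. The effect of chloro with sec-butyl on the nitrogen is also unknown, as is how fluoro or methoxy on the same aromatic carbon would compare with hydrogen and chloro.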